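Anilino to ethylamino on the shared core

A few compounds are considered here, and "the series" means these few. Any claim that something is new, unique, unknown or untested is made for them only; others in the source may bear on it.

In a functional assay on HL-60 cells (Homo sapiens) for cytotoxicity, read by MTT assay, with a stated time of 3 days (on this read-out higher numbers stand for weaker inhibition and lower numbers for stronger inhibition), compound 1 (`N#Cc1c(O)nc(SCc2nc3ccccc3[nH]2)nc1-c1ccccc1`) gives 2.55 nM and compound 2 (`N#Cc1c(Nc2ccccc2)nc(SCc2nc3ccccc3[nH]2)nc1-c1ccccc1`) gives 4.46 nM. For the measured compounds named here, these two values lie within the scatter of each other, so compound 2 cannot be separated from compound 1, its only measured neighbour.

Compound 3 (`CCNc1nc(SCc2nc3ccccc3[nH]2)nc(-c2ccccc2)c1C#N`) has not yet been measured. Its difference from compound 2 is ethyl in place of phenyl on a nitrogen on an aromatic ring. Anilino thus becomes ethylamino, with ethyl in place of phenyl on a nitrogen on an aromatic ring.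

Going by the values given here, only one measured step bears on this change: a 1.7-fold higher number from compound 1 to compound 2 (0.24 log units; within the scatter). That step brought in the anilino group in place of hydroxy on an aromatic carbon, and it stayed within the scatter. Among the compounds with values here, no measured pair exchanges phenyl for ethyl, so the evidence is indirect and gives no direction. No step beyond the scatter is therefore expected in this assay, though the uncertainty is wide.

For compound 3, the expected change is a 1.1-fold lower number from compound 2 to compound 3 (0.05 log units; within the scatter). Compound 3 is estimated at 4 nM, with an expected range from 1.2 nM to 15 nM.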

Compound 3, half-maximal inhibitory concentration: 3.96 nM
Compound 3: the middle estimate sits 1.0-fold (0.00 log units) above what was measured; low and high end bracket the measured number.
By their numbers in this assay, from the lowest: compounds 1, 3 and 2 (each within the scatter of the next).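

In this assay, the exchange of phenyl for ethyl on a nitrogen on an aromatic ring gives a 1.1-fold lower number from compound 2 to compound 3 (0.05 log units; within the scatter) and so cannot be told apart from no change, even though the six-membered aromatic ring of carbon only leaves and the group drops from 6 heavy atoms to 2. Swapping the hydroxy group for ethylamino gives a 1.6-fold higher number from compound 1 to compound 3 (0.19 log units; within the scatter) and also stays inside the usual scatter, so hydroxy, anilino and ethylamino at this place, all on the shared core, now form a set of three that cannot be separated from one another on this read-out. Nothing is available to explain why these three groups cannot be separated.

The compounds shown leave open whether a longer chain such as hexyl, a cyclic amine such as morpholine or a carboxylic acid carried on the ethyl chain would stand apart from these three at this place. They also leave open what a change elsewhere on the shared core would do, since every difference shown lies at this one place.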